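The compounds below may be only part of what the source reports. "The series", "measured", "known", "first", "only" and "open" are said of these compounds alone.

Of the compounds shown here, two have been measured in an assay on isolated protein for inhibition of Leucine-rich repeat serine/threonine-protein kinase 2 (Homo sapiens), read by TR-FRET and LanthaScreen, with stated times of 50 min and 30 min, in the presence of a further agent that is not named here; on this read-out lower numbers stand for stronger inhibition and higher numbers for weaker inhibition. Compound 1 `Cc1c(Nc2nc(N)c3c(C#N)c(N4CCC[C@H]4C)n(C)c3n2)cnn1[C@@H]1CCOC1` gives 20 nM, while compound 2 `C[C@@H]1CCCN1c1c(C(N)=O)c2c(N)ncnc2n1C` gives 3190 nM, the higher of the two numbers, with a gap to compound 1 that lies beyond the usual scatter. Compound 3 `C[C@@H]1CCCN1c1cc2c(N)ncnc2n1C` differs from compound 2 in one place: hydrogen in place of carbamoyl on an aromatic carbon. Among the measured compounds shown here, no measured pair shows this change, so its effect is open. A modest step toward weaker inhibition is expected, a 2.5-fold higher number from compound 2 to compound 3 (0.40 log units; beyond the scatter). For compound 3 the estimate in this assay is 8000 nM, within a range of 2500 nM to 25000 nM.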

Compound 3, half-maximal inhibitory concentration: 6830 nM
Compound 3: middle estimate off by 1.2-fold (0.07 log units), on the high side; the range from low to high includes it.
By their numbers in this assay, from the lowest: compound 1; then compound 2; then compound 3.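

Hydrogen in place of carbamoyl on this aromatic carbon gives a 2.1-fold higher number from compound 2 to compound 3 (0.33 log units; beyond the scatter) in this assay, a modest step that lies beyond the scatter. Among the compounds shown here, this position therefore affects the number, and the first direct comparison here shows that the carbamoyl group is worth only a small part of the large gap separating compound 1 from the other two compounds. No available measurement gives a reason for this step.

On these data alone, it remains open how a carboxylic acid or an aminomethyl group on this carbon would compare with carbamoyl and hydrogen. The size of this step on the core of compound 1 is also unknown.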